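The compounds below may be only part of what the source reports. "The series", "measured", "known", "first", "only" and "open" are said of these compounds alone.

In an ADME assay on MRC5 cells (Homo sapiens), read by MTT assay, with a stated time of 72 h (a lower number here means a stronger inhibitor, a higher number a weaker inhibitor), the compounds measured so far are:
Compound 1 `CN(C)c1ncnc2c1c(-c1ccoc1)cn2[C@@H]1O[C@H](CO)[C@@H](O)[C@H]1O` gives > 100000 nM, a limit.
Compound 2 `Cc1nc(N)c2c(-c3ccoc3)cn([C@@H]3O[C@H](CO)[C@@H](O)[C@H]3O)c2n1` gives > 100000 nM, a limit.
Compound 3 `C#Cc1cn([C@@H]2O[C@H](CO)[C@@H](O)[C@H]2O)c2nc(N)nc(OC)c12` gives > 100000 nM, a limit.

Compound 2 has no numerical value in this assay, only a limit of the assay. It shares that position with the other two compounds: the limit of > 100000 nM in this assay, at which 3 of the 3 values shown sit. Within the data shown here, no measured step between compounds that differ in one place is available, so the series offers no direct guide to the size of the next step.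

Compound 4 `Cc1nc(N)c2c(I)cn([C@@H]3O[C@H](CO)[C@@H](O)[C@H]3O)c2n1` has iodo in place of furan-3-yl on an aromatic carbon, (iodo in place of furan-3-yl on an aromatic carbon). Compound 3 also lacks furan-3-yl and still gives > 100000 nM, which is a limit. Losing furan-3-yl is therefore not expected to produce a large change, although a modest move towards stronger inhibition remains possible, and the reading may well stay at the limit. The expected change is an at least 1.6-fold lower number from compound 2 to compound 4 (0.22 log units; that floor lies within the scatter). For compound 4 the estimate is 60000 nM, with an expected range of 8000 nM to 100000 nM.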

Compound 4, half-maximal inhibitory concentration: 85800 nM
For compound 4 the middle estimate is 1.4-fold (0.16 log units) below the measured one, within the range that was stated.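

In this assay, among these compounds, compound 4 gives 85800 nM, the first reading that is a number and not a limit, so a replacement on this aromatic carbon can bring the reading within the range of the assay. Iodo in place of furan-3-yl gives an at least 1.1-fold lower number from compound 2 to compound 4 (0.06 log units; that floor lies within the scatter), and only this floor can be read, so the true size of the change stays unknown. The floor is all that can be stated because the reading for the furan-3-yl compound is a limit: the limit of > 100000 nM in this assay, at which 3 of the 4 values shown sit.

As far as these compounds go, it remains open whether a small group of another kind on this carbon, such as an amine or a carboxylic acid, or a longer chain, would give a number or stay at the limit. From the compounds shown here alone, it is also open whether iodo in place of furan-3-yl would give a number on the core of compound 1.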